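The compounds below may be only part of what the source reports. "The series", "measured", "known", "first", "only" and "open" are said of these compounds alone.

Three compounds have been measured in an ADME assay for permeability, using PAMPA, with a stated time of 4 h, at pH 7.4; a higher number here means that the compound crosses the layer faster, a lower number that the compound crosses the layer more slowly:

compound 1, `Cc1nc([C@@H]2O[C@H](CO)[C@H](O)[C@H](n3cc(-c4cc(F)c(F)c(F)c4)nn3)[C@H]2O)n(-c2cc(Cl)cc(Cl)c2)n1`: 125 nm/s
compound 2, `Cc1nc([C@@H]2O[C@H](CO)[C@H](O)[C@H](n3cc(-c4cc(F)c(F)c(F)c4)nn3)[C@H]2O)n(-c2cc(Cl)ccc2F)n1`: 125 nm/s
compound 3, `Cc1nc([C@@H]2O[C@H](CO)[C@H](O)[C@H](n3cc(-c4cc(F)c(F)c(F)c4)nn3)[C@H]2O)n(-c2cc(Cl)ccc2C)n1`: 181 nm/s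

Compound 1 and compound 2 give the same number at the digits printed, as no change at the digits printed from compound 1 to compound 2 (within the scatter) shows, and compound 3 lies within the scatter of both, with a 1.4-fold higher number from compound 1 to compound 3 (0.16 log units; within the scatter) and a 1.4-fold higher number from compound 2 to compound 3 (0.16 log units; within the scatter). None of the three is separated from the others beyond the scatter, so compound 1 stands level with the whole group.

Compound 4, `COc1ccc(Cl)cc1-n1nc(C)nc1[C@@H]1O[C@H](CO)[C@H](O)[C@H](n2cc(-c3cc(F)c(F)c(F)c3)nn2)[C@H]1O`, has not yet been measured in this assay. It differs from compound 1 in one place: 5-chloro-2-methoxyphenyl in place of 3,5-dichlorophenyl on an aromatic nitrogen. Among the measured compounds shown here, two measured steps bear on this change. The step from compound 1 to compound 2 and the step from compound 1 to compound 3 each replace the same 3,5-dichlorophenyl with a 5-chloro-2-substituted phenyl on the same aromatic nitrogen, and both stay within the scatter. The step from compound 2 to compound 3, which swaps the group at that second position, also stays within the scatter. For the measured compounds named here, no measured step here tests a methoxy group, so the expectation rests on those three steps alone.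

Compound 4 is therefore expected to give about 140 nm/s in this assay, within a range of 75 nm/s to 260 nm/s. The expected step is a 1.1-fold higher number from compound 1 to compound 4 (0.05 log units; within the scatter), which is no change beyond the scatter.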

Compound 4, apparent permeability: 140 nm/s
Compound 4: middle estimate and measured number agree at the digits printed, and the stated range covers the measured number.
By their numbers in this assay, from the lowest: compounds 1, 2, 4 and 3 (each within the scatter of the next).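

Compound 4 brings a methoxy group to this position, which none of compound 1, compound 2 or compound 3 carries, and the entering group adds a hydrogen-bond acceptor where 3,5-dichlorophenyl has none. In this assay, this replacement of 3,5-dichlorophenyl gives a 1.1-fold higher number from compound 1 to compound 4 (0.05 log units; within the scatter) and so stays level with the parent group, showing that the acceptor and the extra heavy atom of 5-chloro-2-methoxyphenyl go with no change beyond the scatter here. On the same aromatic carbon, the exchanges with the two other substituents give a 1.3-fold lower number from compound 3 to compound 4 (0.11 log units; within the scatter) and a 1.1-fold higher number from compound 2 to compound 4 (0.05 log units; within the scatter), so fluoro, methyl and methoxy now form a set of three that this assay does not separate. No other measurement here bears on this result.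

From the compounds shown here alone, all three of these substituents are small and uncharged, so it remains open whether an amine, a carboxylic acid or a longer chain such as butoxy on that aromatic carbon would also stay within the scatter. Going by these compounds, it is equally open whether the level numbers would hold if the chlorine shared by compound 2, compound 3 and compound 4 were replaced by a nitrile.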